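Trimming a Hydroxymethyl from the Dioxolane Side Chain

This account rests on a few compounds, and the source may have more. Where it says the series, first, only, none or still open, it means among the compounds named here.

Compound 2 `CC1(C)O[C@@H](CO)[C@H](Cn2cc(Cn3c4c(c5ccccc53)C(=O)c3c[n+]([O-])c5ccccc5c3C4=O)nn2)O1` gives the lowest number of the three measured in a functional assay on HCT-116 cells (Homo sapiens) for cytotoxicity, read by MTT assay, with a stated time of 72 h (a lower number here means a stronger inhibitor, a higher number a weaker inhibitor), at 130 nM. Compound 3 `O=C1c2c[n+]([O-])c3ccccc3c2C(=O)c2c1c1ccccc1n2CCCCN1CCCCC1` sits nearest with 200 nM, a gap within the scatter, while compound 1 `CN1CCN(CCCCCn2c3c(c4ccccc42)C(=O)c2c[n+]([O-])c4ccccc4c2C3=O)CC1` lies furthest at 1220 nM. Compound 4 `CC1(C)OC[C@@H](Cn2cc(Cn3c4c(c5ccccc53)C(=O)c3c[n+]([O-])c5ccccc5c3C4=O)nn2)O1` is not yet measured; its change from compound 2 is 2,2-dimethyl-1,3-dioxolan-4-yl in place of 5-(hydroxymethyl)-2,2-dimethyl-1,3-dioxolan-4-yl on a saturated chain carbon bound to an aromatic nitrogen. Among the compounds with values here, the only measured step, a 6.1-fold lower number from compound 1 to compound 3 (0.79 log units; beyond the scatter), swaps one amine for another on the chain and leaves the dioxolane untouched, so it bears only loosely on this change. Within the data shown here, with no step resembling the loss of the hydroxymethyl, one expects a step near zero, a 1.5-fold higher number from compound 2 to compound 4 (0.19 log units; within the scatter), not beyond the scatter. Compound 4 is thus estimated at 200 nM, between 70 nM and 600 nM.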

Compound 4, half-maximal inhibitory concentration: 340 nM
Beside the measured number, compound 4's estimate is 1.7-fold (0.23 log units) below it, and the stated range covers the measured number.
By their numbers in this assay, from the lowest: compounds 2, 3 and 4 (each within the scatter of the next, the first and the last beyond it); then compound 1.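

In this assay, removing the hydroxymethyl gives a 2.6-fold higher number from compound 2 to compound 4 (0.42 log units; beyond the scatter), so the dioxolane side chain on this saturated chain carbon bound to an aromatic nitrogen is not indifferent to change. Within the data shown here, this is the first measured change to that group, whereas the earlier step concerned only the amine on the chain. No measurement shown accounts for the size of this step. The compounds shown leave open whether the hydroxyl or the added carbon carries the difference. A methyl or a methoxymethyl in place of the hydroxymethyl would bear on that question.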